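Swapping cyclohexyl for 4-ethylphenyl on a ring nitrogen

This account rests on a few compounds, and the source may have more. Where it says the series, first, only, none or still open, it means among the compounds named here.

Measured so far:
compound 1 `CN1C(=S)N(C2CCCCC2)C(=O)/C1=C/c1ccc(O)cc1O` — 26000 nM
compound 2 `CN1C(=S)N(C2CCCCC2)C(=O)/C1=C/c1ccc(N(C)C)cc1` — 12300 nM
compound 3 `Cc1ccc(N2C(=O)/C(=C/c3ccc(O)cc3O)N(C)C2=S)cc1` — 27100 nM

In an assay for inhibition of NADPH oxidase 1 (Homo sapiens), read by chemiluminescence (on this read-out higher numbers stand for weaker inhibition and lower numbers for stronger inhibition), compound 2 gives the lowest number of the three, so it is the strongest inhibitor of this small group. Compound 4 `CCc1ccc(N2C(=O)/C(=C/c3ccc(N(C)C)cc3)N(C)C2=S)cc1` is not yet measured. It differs from compound 2 by 4-ethylphenyl in place of cyclohexyl on an amide-type nitrogen in a ring. Among the measured compounds shown here, the one measured step that bears on this, a related change of cyclohexyl to 4-methylphenyl on the same ring nitrogen, was a 1.0-fold higher number from compound 1 to compound 3 (0.02 log units; within the scatter). A similar outcome is therefore expected here: the step from compound 2 to compound 4 is estimated as a 1.0-fold higher number from compound 2 to compound 4 (0.01 log units; within the scatter), with no shift beyond the scatter. Compound 4 is expected to give about 12500 nM in this assay, within a range of 5000 nM to 32000 nM.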

Compound 4, inhibition constant: 4390 nM
Compound 4: the middle estimate sits 2.8-fold (0.45 log units) above what was measured, outside the stated range (below it).
By their numbers in this assay, from the lowest: compound 4; then compound 2; then compounds 1 and 3 (each within the scatter of the next).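

In this assay the ring nitrogen proves able to move the number: 4-ethylphenyl in place of cyclohexyl gives a 2.8-fold lower number from compound 2 to compound 4 (0.45 log units; beyond the scatter). The related 4-methylphenyl change gave a 1.0-fold higher number from compound 1 to compound 3 (0.02 log units; within the scatter) and stayed within the scatter, so a swap at this nitrogen does not always have the same outcome. Nothing measured here gives a reason for this contrast.

The two steps differ both in the entering group and in the rest of the molecule, and the compounds shown cannot separate these. As far as these compounds go, how a longer chain such as 4-propylphenyl, or an amine on the phenyl ring, would behave at this nitrogen also stays open.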